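Chloro for Bromo on a Weakly Cytotoxic Core

This account rests on a few compounds, and the source may have more. Where it says the series, first, only, none or still open, it means among the compounds named here.

Of the compounds shown here, two built on a shared core have been measured so far in a functional assay on MDA-MB-468 cells (Homo sapiens) for cytotoxicity, read by sulforhodamine B assay, with a stated time of 48 h; a lower number here means a stronger inhibitor of growth, a higher number a weaker inhibitor of growth. Compound 1 `CCN(CC)CN1C(=O)/C(=N\c2nc3ccc(C)cc3s2)c2ccccc21` gives 63500 nM in this assay. Compound 2 `CCN(CC)CN1C(=O)/C(=N\c2nc3ccc(C)cc3s2)c2c(Br)cccc21`, which carries a bromo in place of hydrogen on an aromatic carbon, gives 43100 nM in this assay. That change amounts to a 1.5-fold lower number from compound 1 to compound 2 (0.17 log units; within the scatter). Among the two numbers compound 2 holds the lower one, but its only neighbour is compound 1 and that gap lies within the scatter, so no ranking can be read from it.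

Compound 3 `CCN(CC)CN1C(=O)/C(=N\c2nc3ccc(C)cc3s2)c2c(Cl)cccc21` has not yet been measured. It differs from compound 2 by chloro in place of bromo on an aromatic carbon. Among the compounds with values here, the one measured step that touches this ring position is a 1.5-fold lower number from compound 1 to compound 2 (0.17 log units; within the scatter), where introducing the halogen itself shifted the number only within the scatter. Swapping one halogen for another at the same carbon is a smaller alteration than adding one, so no move beyond the scatter is expected in this assay. Compound 3 is therefore estimated to give 50000 nM, with a range of 20000 nM to 120000 nM. The implied step, a 1.2-fold higher number from compound 2 to compound 3 (0.06 log units; within the scatter), is expected to stay within the scatter.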

Compound 3, concentration for 50% growth inhibition: 27300 nM
The estimate for compound 3 lay 1.8-fold (0.26 log units) above the measured number; low and high end bracket the measured number.
By their numbers in this assay, from the lowest: compounds 3, 2 and 1 (each within the scatter of the next, the first and the last beyond it).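

Within the data shown here, with compound 3, a halogen on this aromatic carbon produces a step beyond the scatter for the first time in this assay: chloro in place of hydrogen gives a 2.3-fold lower number from compound 1 to compound 3 (0.37 log units; beyond the scatter) and so moves the number modestly, whereas the bromo step from the unsubstituted compound stayed within the scatter. The direct exchange of the two halogens gives a 1.6-fold lower number from compound 2 to compound 3 (0.20 log units; within the scatter) and lies within the scatter, so this assay does not separate chloro from bromo at this carbon, even though only the chloro compound stands beyond the scatter from compound 1. No measurement is available that would explain either step, and the data therefore describe the size of these changes without accounting for them.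

The compounds shown leave open how a fluoro, a methoxy or an amine on this same aromatic carbon would compare with chloro and bromo. They also leave open whether the step from hydrogen to chloro would persist if the shared core were changed elsewhere, for example with a longer chain in place of the ethyl groups.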